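Chloro to Cyano on the Benzyl Arm of Compound 2

The source may hold more compounds than are shown below. What is called first, only, known or untested is meant among the compounds shown, and "the series" means these compounds.

Of the compounds shown here, two sharing one core have been measured in an assay on isolated protein for inhibition of DNA nucleotidylexotransferase (Homo sapiens), read by scintillation counting, with a stated time of 10 min; a lower number here means a stronger inhibitor, a higher number a weaker inhibitor. Compound 1 `O=C(/C=C/c1cn(-c2ccc(Cl)cc2)c2ccccc12)CC(=O)C(=O)O` gives 31 uM, and compound 2 `O=C(/C=C/c1cn(Cc2ccc(Cl)cc2)c2ccccc12)CC(=O)C(=O)O` gives 10 uM. Going by the values given here, the single step between them, a 3.1-fold lower number from compound 1 to compound 2 (0.49 log units; beyond the scatter), exchanges the group on the ring nitrogen. Among the compounds with values here, compound 2 thus holds the lowest of the two numbers, with compound 1 as its only neighbour at a distance beyond the scatter.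

Compound 3 `N#Cc1ccc(Cn2cc(/C=C/C(=O)CC(=O)C(=O)O)c3ccccc32)cc1` keeps the 4-chlorobenzyl linkage of compound 2 but carries cyano in place of chloro on an aromatic carbon, turning the 4-chlorobenzyl into a 4-cyanobenzyl. Within the data shown here, no measured step touches this position: the one step from compound 1 to compound 2 altered the linker between the ring nitrogen and the chlorophenyl, not the group at the far end of that ring. There is therefore nothing to indicate a direction, and a step for compound 3 within the scatter of this assay is expected, namely no change at the digits printed from compound 2 to compound 3 (within the scatter). Compound 3 is accordingly estimated at 10 uM, with a likely range from 4 uM to 25 uM.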

Compound 3, concentration for 50% inhibition: 1.4 uM
For compound 3 the middle estimate is 7.1-fold (0.85 log units) above the measured one, and the stated range ends above it.
By their numbers in this assay, from the lowest: compound 3; then compound 2; then compound 1.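

Going by these compounds alone, the far end of the benzyl arm turns out to matter to this inhibition: in this assay there is a 7.1-fold lower number from compound 2 to compound 3 (0.85 log units; beyond the scatter) when cyano takes the place of chloro on the aromatic carbon para to a large group, a step beyond the scatter at a position that no earlier pair had tested. Together with the change on the ring nitrogen, the arm now accounts for a 22-fold lower number from compound 1 to compound 3 (1.35 log units; beyond the scatter) and leaves compound 3 with the lowest number of the three, its steps to both others being beyond the scatter. Nothing at hand bears on the reason for this result.

The compounds shown leave open whether the drop in the number is particular to the cyano group or would also appear with another group at that place, such as a carboxylic acid, an amine or a methoxy group. They also leave open whether cyano would do the same on the 4-chlorophenyl arm of compound 1 as a 4-cyanophenyl group, or on a longer chain between the ring nitrogen and the aromatic ring.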